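Methyl to Ethyl on the Macrocycle Chain of Compound 3

This account rests on a few compounds, and the source may have more. Where it says the series, first, only, none or still open, it means among the compounds named here.

Compound 3 `COc1cnc(O[C@@H]2C[C@H]3C(=O)N[C@]4(C(=O)NS(=O)(=O)C5CC5)C[C@H]4/C=C\CCCC[C@@H](C)[C@H](NC(=O)OC(C)(C)C(F)(F)F)C(=O)N3C2)c2cc(Cl)ccc12` stands highest of the three compounds measured in an ADME assay on microsomes from liver (Homo sapiens) for metabolic stability, read by LC-MS, using NADPH, with a stated time of 45 min (a lower number here means that the compound disappears faster, a higher number that the compound lasts longer), where compound 3 gives 0.505 h. Compound 2 `COc1cnc(O[C@@H]2C[C@H]3C(=O)N[C@]4(C(=O)NS(=O)(=O)C5CC5)C[C@H]4/C=C\CCCC[C@@H](C)[C@H](NC(=O)OC(C)(C)C)C(=O)N3C2)c2cc(Cl)ccc12` gives 0.192 h in this assay, and compound 1 `COc1cnc(O[C@@H]2C[C@H]3C(=O)N[C@]4(C(=O)NS(=O)(=O)C5CC5)C[C@H]4/C=C\CCCCC[C@H](NC(=O)OC(C)(C)C)C(=O)N3C2)c2cc(Cl)ccc12` gives 0.107 h. Compound 3 stands beyond the scatter from compound 2 and from compound 1. Compound 3 is the longest-lived of the set. The two measured steps are a 1.8-fold higher number from compound 1 to compound 2 (0.25 log units; within the scatter) and a 2.6-fold higher number from compound 2 to compound 3 (0.42 log units; beyond the scatter).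

Compound 4 `CC[C@@H]1CCCC/C=C\[C@@H]2C[C@@]2(C(=O)NS(=O)(=O)C2CC2)NC(=O)[C@@H]2C[C@@H](Oc3ncc(OC)c4ccc(Cl)cc34)CN2C(=O)[C@H]1NC(=O)OC(C)(C)C(F)(F)F` differs from compound 3 in one place: methyl in place of hydrogen on a saturated chain carbon bound to a saturated ring carbon. Among the compounds with values here, the one measured step that bears on this change is a 1.8-fold higher number from compound 1 to compound 2 (0.25 log units; within the scatter), which added the same group at a different saturated carbon and moved the number upward only within the scatter. The step of a 2.6-fold higher number from compound 2 to compound 3 (0.42 log units; beyond the scatter) concerns a different group and offers no direct guidance. Compound 4 is therefore expected to show a step of a 1.2-fold higher number from compound 3 to compound 4 (0.07 log units; within the scatter) in this assay, which is expected to remain within the scatter. Compound 4 is estimated at 0.6 h in this assay, with a range from 0.3 h to 1.2 h.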

Compound 4, half-life: 0.8 h
The estimate for compound 4 lay 1.3-fold (0.12 log units) below the measured number, and the stated range covers the measured number.
By their numbers in this assay, from the lowest: compounds 1 and 2 (each within the scatter of the next); then compounds 3 and 4 (each within the scatter of the next).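

In this assay the change from methyl to ethyl gives a 1.6-fold higher number from compound 3 to compound 4 (0.20 log units; within the scatter) and so does not separate the two compounds, which shows that this place, a saturated chain carbon bound to a saturated ring carbon, accepts one more carbon with no change that can be read beyond the scatter. Within the data shown here, the earlier compounds held only a 1.8-fold higher number from compound 1 to compound 2 (0.25 log units; within the scatter) as a comparable step, with a methyl entering at a saturated ring carbon and without the trifluoromethyl group, so the present step is the first reading of an added methyl at this place and with that group present. No measurement shown here gives a reason for this result.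

On these data alone, what a longer chain such as propyl, a branched isopropyl or a chain ending in a hydroxyl group or an amine would do at this place remains open, since a single step from methyl to ethyl does not show how far the place can be extended. Also open, as far as these compounds go, is how the ethyl group would read with the plain tert-butyl carbamate of compound 2 in place of the trifluoromethyl group.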